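Chain extension on the side arm: outlook for compound 4

The source may report more compounds than this note shows. Statements on the series, on what has been measured and on what is new or still open speak of the compounds shown alone.

Measured in a functional assay on SGC-7901 cells (Homo sapiens) for cytotoxicity, read by MTT assay, with a stated time of 72 h (a lower number here means a stronger inhibitor, a higher number a weaker inhibitor), so far:
compound 1 `CN(C)CCNc1nc(N/N=C/c2nccn2Cc2ccccc2)nc2ccccc12`: 4300 nM
compound 2 `Cc1ccc(Cn2ccnc2/C=N/Nc2nc(NCCN(C)C)c3ccccc3n2)cc1`: 2750 nM
compound 3 `CN(C)CCNc1nc(N/N=C/c2nccn2Cc2cccc(Cl)c2Cl)nc2ccccc12`: 1850 nM

Compound 2 differs from both neighbours only within the scatter: a 1.6-fold lower number from compound 1 to compound 2 (0.19 log units; within the scatter) and a 1.5-fold lower number from compound 2 to compound 3 (0.17 log units; within the scatter). Among the compounds with values here, the one step that reaches beyond the scatter, a 2.3-fold lower number from compound 1 to compound 3 (0.37 log units; beyond the scatter), is modest and concerns the aryl group of the benzyl arm.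

Compound 4 `Cc1ccc(Cn2ccnc2/C=N/Nc2nc(NCCCN(C)C)c3ccccc3n2)cc1` keeps everything of compound 2 except the side arm, where ((dimethylamino)methyl in place of dimethylamino on a saturated chain carbon, two bonds along the chain from a nitrogen on an aromatic ring). Within the data shown here, no measured pair in this assay touches that arm: all three steps vary the benzyl substitution. Among the measured compounds shown here, the only evidence is therefore that this assay has moved little across the whole series, and nothing points to a direction for this change.

The expectation is accordingly a step from compound 2 to compound 4 of no change at the digits printed from compound 2 to compound 4 (within the scatter), that is, nothing beyond the scatter. Compound 4 is estimated at 2750 nM in this assay, with a range from 1100 nM to 7000 nM expected to cover it.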

Compound 4, half-maximal inhibitory concentration: 2600 nM
The estimate for compound 4 lay 1.1-fold (0.02 log units) above the measured number; measured number inside the range.
By their numbers in this assay, from the lowest: compounds 3, 4, 2 and 1 (each within the scatter of the next, the first and the last beyond it).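

In this assay, within the data shown here, the step of a 1.1-fold lower number from compound 2 to compound 4 (0.02 log units; within the scatter) gives the first reading on the side arm, since every earlier step varied only the benzyl arm. For this one pair, (dimethylamino)methyl in place of dimethylamino on a saturated chain carbon, two bonds along the chain from a nitrogen on an aromatic ring, leaves the number within the scatter, so this extension by one chain carbon brings no readable gain or loss. No measurement is available that would account for this result.

The compounds shown leave open whether a still longer chain, such as 4-(dimethylamino)butyl, or a ring amine such as morpholine or piperidine at the end of the arm, would also stay within the scatter. They also leave open whether the 3-(dimethylamino)propyl arm behaves the same way alongside the 2,3-dichlorophenyl group of compound 3.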